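The source may hold more compounds than are shown below. What is called first, only, known or untested is meant among the compounds shown, and "the series" means these compounds.

Compounds 1, 2 and 3 share a two-armed core carrying an amide on one side and a sulfonamide on the other. Compound 1 `O=C(NCc1ccc(CNS(=O)(=O)c2ccc3c(c2)CCO3)cc1)c1cccc2c1COC2` gives 40% in an assay on cells for inhibition of C-X-C chemokine receptor type 4 (Homo sapiens), with a stated time of 22 h, tested at 100 nM (on this read-out lower numbers stand for less inhibition and higher numbers for more inhibition at the one concentration tested (going by the name of the read-out)), and compound 2 `Cc1nnsc1C(=O)NCc1ccc(CNS(=O)(=O)c2ccc(F)c(F)c2)cc1` gives 40% in this assay. Compound 3 `Cc1cc(C(=O)NCc2ccc(CNS(=O)(=O)c3ccc4c(c3)CCO4)cc2)n(C)n1` is reported in this assay only as "active" (no number reported), so no number places it against compound 1 or compound 2. Compound 4 `Cn1nccc1C(=O)NCc1ccc(CNS(=O)(=O)c2ccc3c(c2)CCO3)cc1` differs from compound 3 by hydrogen in place of methyl on an aromatic carbon. Among the measured compounds shown here, no measured step between these two compounds exists, and the change is small, so the step in this assay is expected to stay within the scatter, with no clear direction. Compound 4 is estimated to give about 40% in this assay, within 20% to 60%.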

Compound 4, a percentage reported as inhibition, at one concentration (the size of the read-out at that concentration, not a potency): 40%
Compound 4: the middle estimate sits on the measured number at the digits printed; the measured number falls inside the stated range.
By their numbers in this assay, from the lowest: compounds 1, 2 and 4 (each within the scatter of the next).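

Among the compounds shown here, compound 4 gives the first readable step at this carbonyl carbon: in this assay, the group of 6 heavy atoms with one five-membered aromatic ring replaces the group of 9 heavy atoms with two rings, with no change at the digits printed from compound 1 to compound 4 (within the scatter). On this pair, the smaller group holds the read-out level with the larger one. The methyl-to-hydrogen step from compound 3 cannot be read, and no measured evidence bears on this result.

The compounds shown leave open how an amine or a carboxylic acid on that aromatic carbon would read in this assay, and whether a longer chain would read the same.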